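This account rests on a few compounds, and the source may have more. Where it says the series, first, only, none or still open, it means among the compounds named here.

Compound 2 `CC(C)(C)c1cc(C(=O)Nc2ccccc2)n(Cc2ccccc2)n1` stands highest of the three measured compounds in a physicochemical assay for lipophilicity, read by HPLC, at pH 7.4 (a higher number here means a more lipophilic compound, a lower number a more polar compound), where compound 2 gives 4.7. Compound 3 `NCc1csc(NC(=O)c2cn(Cc3ccccc3)nn2)n1` gives 1.4, and compound 1 `NCc1csc(NC(=O)c2cnn[nH]2)n1` gives -0.3; both of these gaps to compound 2 are beyond the scatter. Compound 4 `CC(C)(C)c1cc(C(=O)Nc2nc(CO)cs2)n(Cc2ccccc2)n1` has not yet been measured. It differs from compound 2 in one place: 4-(hydroxymethyl)-1,3-thiazol-2-yl in place of phenyl on an amide-type nitrogen. Going by the values given here, no pair of measured compounds shares this exact change, so the size of the step is uncertain, but a decrease is expected because compound 2 starts from 4.7. The expected step of a number 1.70 log units lower from compound 2 to compound 4 (beyond the scatter) is downward. Compound 4 is estimated at 3, with a likely range from 2.2 to 3.8.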

Compound 4, distribution coefficient: 3.4
Compound 4: middle estimate off by 0.40 log units, on the low side; the range from low to high includes it.
By their numbers in this assay, from the lowest: compound 1; then compound 3; then compound 4; then compound 2.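

In this assay, going by these compounds alone, the change on the amide-type nitrogen gives the first step that can be read between measured compounds differing in one place: a number 1.30 log units lower from compound 2 to compound 4 (beyond the scatter). It shows that this position is not silent in this assay, since exchanging phenyl for 4-(hydroxymethyl)-1,3-thiazol-2-yl moves the number by more than the scatter. Nothing on hand explains the size of this step.

The compounds shown leave open how much of the step belongs to the ring and how much to the hydroxymethyl. They also leave open how a carboxylic acid or a methoxymethyl group in place of the hydroxymethyl would read.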